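This account rests on a few compounds, and the source may have more. Where it says the series, first, only, none or still open, it means among the compounds named here.

Working notes on the series.

Three compounds share one core and differ only on the saturated chain carbon bound to an amide-type nitrogen and a carbonyl carbon. Compound 1 `O=C(CN(c1ncnc2c1ncn2C1CCCCO1)C1CC1)N[C@@H](CCC(=O)OCc1ccccc1)C(=O)OCc1ccccc1` gives 14.1% in a functional assay on the whole organism (Tail, strain ICR) with Mus musculus as the target, in the tail flick test, with a stated time of 150 min, at a dose of 25 umol/kg by the oral route; on this read-out lower numbers stand for a weaker effect and higher numbers for a stronger effect at the one dose given. Compound 2 `O=C(CN(c1ncnc2c1ncn2C1CCCCO1)C1CC1)NCC(=O)OCc1ccccc1` gives 7.26%, and compound 3 `C[C@@H](O)[C@H](NC(=O)CN(c1ncnc2c1ncn2C1CCCCO1)C1CC1)C(=O)OCc1ccccc1` gives 6.53%. The three numbers sit close together: a number 6.8 percentage points lower from compound 1 to compound 2 (within the scatter), a number 7.6 percentage points lower from compound 1 to compound 3 (within the scatter), and a number 0.7 percentage points lower from compound 2 to compound 3 (within the scatter). Compound 3 therefore stands among values that cannot be told apart, with compound 2 nearest and compound 1 furthest.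

Compound 4 `O=C(CN(c1ncnc2c1ncn2C1CCCCO1)C1CC1)N[C@@H](CO)C(=O)OCc1ccccc1` differs from compound 3 by hydrogen in place of methyl on a saturated chain carbon bound to an oxygen on a saturated carbon and a saturated chain carbon. Going by the values given here, no measured step touches this exact position. The nearest information is the step from compound 2 to compound 3, where 1-hydroxyethyl replaced hydrogen at the neighbouring chain carbon and the numbers stayed within the scatter; the steps from compound 1 likewise stayed within the scatter. A small trim of the same side group is thus expected to give no step beyond the scatter, and the estimated step is a number 0.5 percentage points higher from compound 3 to compound 4 (within the scatter). Compound 4 is expected to give about 7% in this assay, with a range from 0% to 18%.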

Compound 4, a percentage reported as activity, at one dose (the size of the read-out at that dose, not a potency): 18.3%
For compound 4 the middle estimate is 11.3 percentage points below the measured one; the measured number lies above the stated range.
By their numbers in this assay, from the lowest: compounds 3, 2, 1 and 4 (each within the scatter of the next, the first and the last beyond it).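

Going from 1-hydroxyethyl to hydroxymethyl in this assay gives a number 11.8 percentage points higher from compound 3 to compound 4 (beyond the scatter), the first step in the series beyond the scatter, so the methyl on this saturated chain carbon matters even though the side group otherwise stays the same. Set against hydrogen, hydroxymethyl gives a number 11 percentage points higher from compound 2 to compound 4 (beyond the scatter) while 1-hydroxyethyl gives a number 0.7 percentage points lower from compound 2 to compound 3 (within the scatter), so among these compounds a hydroxy-bearing side group separates from hydrogen only without the methyl. Hydroxy in place of (benzyloxycarbonyl)methyl gives a number 4.2 percentage points higher from compound 1 to compound 4 (within the scatter), leaving these two side groups indistinguishable here.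

Nothing at hand accounts for the effect of the methyl. On these data alone, whether an amine or a carboxylic acid in place of the hydroxy, or a longer chain carrying the hydroxy, would hold the number at the level of compound 4 remains open.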